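Swapping the aryl hydrazone in a triazolyl-pyridine urea series

The source may hold more compounds than are shown below. What is called first, only, known or untested is meant among the compounds shown, and "the series" means these compounds.

Measured compounds:
- compound 1, `CN(C)CCn1cnnc1-c1cc(Oc2ccc(NC(=O)N/N=C/c3c(Cl)cccc3Cl)cc2F)ccn1`, 280 nM
- compound 2, `COc1ccc(/C=N/NC(=O)Nc2ccc(Oc3ccnc(-c4nncn4CCN(C)C)c3)c(F)c2)c(OC)c1OC`, 3970 nM

Compound 2 stands at the higher of the two numbers in a functional assay on HT-29 cells (Homo sapiens) for cytotoxicity, read by MTT assay, with a stated time of 72 h; on this read-out higher numbers stand for weaker inhibition and lower numbers for stronger inhibition; the nearest is compound 1, which sits far lower. For the measured compounds named here, the one step measured so far, a 14-fold higher number from compound 1 to compound 2 (1.15 log units; beyond the scatter), is large and lies well beyond the scatter.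

Compound 3, `CN(C)CCn1cnnc1-c1cc(Oc2ccc(NC(=O)N/N=C/c3cccc(Cl)c3Cl)cc2F)ccn1`, has not yet been measured. Its change from compound 2 is 2,3-dichlorophenyl in place of 2,3,4-trimethoxyphenyl on a carbon with a double bond to nitrogen. Compound 2 carries the group whose arrival in the step from compound 1 brought the large rise, so the return to a dichlorophenyl bears directly on compound 3; the chlorine pattern differs from that of compound 1, however, so the full reversal is not assured. A lower number is expected for compound 3, the step of a 7.9-fold lower number from compound 2 to compound 3 (0.90 log units; beyond the scatter) being estimated from the reversed direction of the earlier step. The expected value for compound 3 is 500 nM, with a range from 150 nM to 1700 nM.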

Compound 3, half-maximal inhibitory concentration: 130 nM
Estimate against measurement, compound 3: 3.8-fold (0.59 log units) above, and the stated range ends above it.
By their numbers in this assay, from the lowest: compound 3; then compound 1; then compound 2.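

The change gives a 31-fold lower number from compound 2 to compound 3 (1.48 log units; beyond the scatter) in this assay, so the high number of compound 2 is tied to the 2,3,4-trimethoxyphenyl group on this carbon and not to the shared core. The placing of the two chlorines can also be read here: the 2,3-dichlorophenyl group in place of 2,6-dichlorophenyl gives a 2.2-fold lower number from compound 1 to compound 3 (0.33 log units; beyond the scatter), a modest step that still lies beyond the scatter. Nothing available explains either step.

The compounds shown leave open whether both chlorines are needed, and how a phenyl ring with a single chlorine, a bromine in place of chlorine, or a pyridine ring would read at this carbon. They also cannot show whether the order seen here carries over to any other cell line.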